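The source may report more compounds than this note shows. Statements on the series, on what has been measured and on what is new or still open speak of the compounds shown alone.

Compound 1 `Cc1ccc(CCOc2ccc(-c3c(C)nc(C)c([C@H](OC(C)(C)C)C(=O)O)c3N3CCC(C)(C)CC3)cc2)cc1` in a toxicity assay on MT2 cells (Homo sapiens) for cytotoxicity, read by XTT assay, with a stated time of 4 days (a higher number here means that more compound is tolerated, a lower number that less compound is tolerated), gives >= 33500 nM, which is a limit of the assay.
Compound 2 `Cc1nc(C)c([C@H](OC(C)(C)C)C(=O)O)c(N2CCC(C)(C)CC2)c1-c1ccc(OCCc2ccc(C#N)cc2)cc1` in this assay gives >= 33500 nM, again a limit.
Compound 3 `Cc1nc(C)c([C@H](OC(C)(C)C)C(=O)O)c(N2CCC(C)(C)CC2)c1-c1ccc(OCCc2ccc(F)cc2F)cc1` in this assay gives >= 33500 nM, also a limit.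

For the measured compounds named here, compound 3 therefore stands where every value so far stands: at the limit, (the limit of >= 33500 nM in this assay, at which 3 of the 3 values shown sit). The three steps among the measured compounds, a step that the two limits leave unreadable from compound 1 to compound 2, a step that the two limits leave unreadable from compound 1 to compound 3 and a step that the two limits leave unreadable from compound 2 to compound 3, cannot be read in size, so none of them tells how strongly a change at this place moves the number.

Compound 4 `Cc1nc(CCOc2ccc(-c3c(C)nc(C)c([C@H](OC(C)(C)C)C(=O)O)c3N3CCC(C)(C)CC3)cc2)cs1` carries the change (2-methyl-1,3-thiazol-4-yl in place of 2,4-difluorophenyl on a saturated chain carbon, two bonds along the chain from an oxygen on an aromatic ring). With only limits to go by, no step beyond the scatter is expected in this assay in either direction, and the estimated step is a number no higher from compound 3 to compound 4 (the limit leaves the size open). Compound 4 is expected to give about 33500 nM, within 17000 nM to 67000 nM.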

Compound 4, half-maximal cytotoxic concentration: >= 25000 nM
Compound 4: a limit, no number (the forecaster's own chance of this, stated with the estimate: 85%); the middle value lies beyond the limit too.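

Compound 4 gives >= 25000 nM, which is a limit of the assay, and its steps from compound 1, compound 2 and compound 3 cannot be read in size. The compounds shown leave open at what concentration any of them harms the cells in this assay, and whether changing the ring on the chain moves that concentration at all.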